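Compound 3 to compound 4: trifluoromethyl in place of nitro

This account rests on a few compounds, and the source may have more. Where it says the series, first, only, none or still open, it means among the compounds named here.

In a functional assay on MDA-MB-231 cells (Homo sapiens) for antiproliferative activity, read by MTT assay, with a stated time of 72 h (on this read-out lower numbers stand for stronger inhibition and higher numbers for weaker inhibition), compound 1 `CC1=CC[C@H]2[C@H](CC[C@]2(C)O)C(C)(C)[C@@H]1CC[C@H]1[C@]2(C)CC[C@H](OC(=O)c3ccncc3)C(C)(C)O[C@H]2CC[C@@]1(C)O` gives 18000 nM, compound 2 `CC1=CC[C@H]2[C@H](CC[C@]2(C)O)C(C)(C)[C@@H]1CC[C@H]1[C@]2(C)CC[C@H](OC(=O)NCc3ccccc3)C(C)(C)O[C@H]2CC[C@@]1(C)O` gives 40300 nM and compound 3 `CC1=CC[C@H]2[C@H](CC[C@]2(C)O)C(C)(C)[C@@H]1CC[C@H]1[C@]2(C)CC[C@H](OC(=O)c3cccc([N+](=O)[O-])c3)C(C)(C)O[C@H]2CC[C@@]1(C)O` gives 34700 nM. Compound 3 stands within the scatter of both other values. The steps to it read a 1.2-fold lower number from compound 2 to compound 3 (0.06 log units; within the scatter) and a 1.9-fold higher number from compound 1 to compound 3 (0.29 log units; within the scatter). Only a 2.2-fold higher number from compound 1 to compound 2 (0.35 log units; beyond the scatter) goes beyond the scatter, and it is modest.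

Compound 4 `CC1=CC[C@H]2[C@H](CC[C@]2(C)O)C(C)(C)[C@@H]1CC[C@H]1[C@]2(C)CC[C@H](OC(=O)c3cccc(C(F)(F)F)c3)C(C)(C)O[C@H]2CC[C@@]1(C)O` keeps the shared core and carries trifluoromethyl in place of nitro on an aromatic carbon, meta to a large group: trifluoromethyl in place of nitro on an aromatic carbon. Among the compounds with values here, no measured step changes this substituent alone, so the evidence is indirect. Exchanging the entire group on the carbonyl carbon gave, as the largest step, a 2.2-fold higher number from compound 1 to compound 2 (0.35 log units; beyond the scatter). A smaller exchange is therefore expected to produce no step beyond the scatter in this assay, in either direction. The estimated step is a 1.1-fold lower number from compound 3 to compound 4 (0.04 log units; within the scatter). Compound 4 is expected at about 32000 nM, with an estimated range of 16000 nM to 62000 nM.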

Compound 4, half-maximal inhibitory concentration: 36300 nM
Compound 4: the middle estimate sits 1.1-fold (0.05 log units) below what was measured; measured number inside the range.
By their numbers in this assay, from the lowest: compounds 1, 3, 4 and 2 (each within the scatter of the next, the first and the last beyond it).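

In this assay, within the data shown here, a 1.0-fold higher number from compound 3 to compound 4 (0.02 log units; within the scatter) gives the first direct reading at this aromatic carbon: exchanging nitro for trifluoromethyl, which removes the hydrogen-bond acceptors of nitro, leaves no step beyond the scatter. The whole-group exchanges on the carbonyl carbon read a 1.1-fold lower number from compound 2 to compound 4 (0.05 log units; within the scatter) and a 2.0-fold higher number from compound 1 to compound 4 (0.30 log units; within the scatter), so 3-(trifluoromethyl)phenyl lies within the scatter of both benzylamino and pyridin-4-yl, even though those two are separated by a step beyond it. No measurement at hand offers an explanation for these results.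

Still open, as far as these compounds go, is whether an amine or a carboxylic acid on this aromatic carbon would give a step beyond the scatter from compound 3. Also open, from the compounds shown here alone, is whether the match between nitro and trifluoromethyl holds outside this assay.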